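Two Sulfonamide Anilides Both at the Assay Limit

This account rests on a few compounds, and the source may have more. Where it says the series, first, only, none or still open, it means among the compounds named here.

Compound 1 `COc1ccc(Nc2ncnc3cc(OC)c(OCCCCC(=O)Nc4ccc(S(N)(=O)=O)cc4)cc23)cc1`: > 40000 nM
Compound 2 `COc1cc2ncnc(Nc3cc(F)c(F)c(F)c3)c2cc1OCCCCC(=O)Nc1ccc(S(N)(=O)=O)cc1`: > 40000 nM

In a functional assay on A549 cells (Homo sapiens) for antiproliferative activity, read by MTT assay, with a stated time of 72 h (on this read-out lower numbers stand for stronger inhibition and higher numbers for weaker inhibition), compound 1 gives > 40000 nM, which is a limit of the assay and not a number. In this assay compound 2 gives > 40000 nM, likewise a limit. The step that the two limits leave unreadable from compound 1 to compound 2 is therefore unreadable. Compound 3 `COc1cc2ncnc(Nc3ccc(C(F)(F)F)cc3)c2cc1OCCCCC(=O)Nc1ccc(S(N)(=O)=O)cc1` differs from compound 2 by 4-(trifluoromethyl)phenyl in place of 3,4,5-trifluorophenyl on a nitrogen on an aromatic ring. Both measured values sit at the limit (the limit of > 40000 nM in this assay, at which 2 of the 2 values shown sit), so no readable step bears on this change and no direction can be predicted. Compound 3 is estimated at 60000 nM, within 20000 nM to 200000 nM, most probably again a limit. The step that the limit leaves unreadable from compound 2 to compound 3 is expected to stay within the scatter.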

Compound 3, half-maximal inhibitory concentration: 14800 nM
Estimate against measurement, compound 3: 4.1-fold (0.61 log units) above, and the stated range ends above it.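

The group on the nitrogen can bring a readable number after all: in this assay 4-(trifluoromethyl)phenyl in place of 3,4,5-trifluorophenyl gives an at least 2.7-fold lower number from compound 2 to compound 3 (0.43 log units; beyond the scatter) and trifluoromethyl in place of methoxy on an aromatic carbon gives an at least 2.7-fold lower number from compound 1 to compound 3 (0.43 log units; beyond the scatter) with the rest of the molecule unchanged. Each step starts from a limit of the assay and not a number, so only its smallest size is known: the limit of > 40000 nM in this assay, at which 2 of the 3 values shown sit.

A nitrile or a chlorine in place of the trifluoromethyl could show whether the trifluoromethyl itself matters. From the compounds shown here alone, whether a carboxylic acid in place of the sulfonamide changes the number also stays open.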